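Benzyl purine series: loss of one ring chloro

The source may hold more compounds than are shown below. What is called first, only, known or untested is meant among the compounds shown, and "the series" means these compounds.

Of the compounds shown here, three of the shared core have numbers so far. In a functional assay on KM12 cells (Homo sapiens) for cytotoxicity, read by sulforhodamine B assay, with a stated time of 48 h (a higher number here means a weaker inhibitor of growth, a lower number a stronger inhibitor of growth), compound 2 `ClCc1ccc(Cn2cnc3nc(Cl)nc(Cl)c32)cc1` gives 260 nM, the lowest number of the three. The nearest is compound 1 `ClCc1cccc(Cn2cnc3ncnc(Cl)c32)c1`, which in this assay gives 1860 nM, a gap beyond the scatter. The furthest is compound 3 `ClCc1ccccc1Cn1cnc2nc(Cl)nc(Cl)c21`, which in this assay gives 11700 nM, again beyond the scatter. Going by the values given here, none of these three pairs differ in only one place, so no single step can be read from the measured set; compound 1 and compound 3 differ from compound 2 in two respects each, and their values show only that compound 2 stands apart from both.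

Compound 4 `ClCc1ccc(Cn2cnc3ncnc(Cl)c32)cc1` is not yet measured. It differs from compound 2 by hydrogen in place of chloro on an aromatic carbon, between two ring nitrogen atoms of the fused core. Among the compounds with values here, no measured pair isolates this change. The direction rests on no shown step. The expectation is a weakening of moderate size, a 3.1-fold higher number from compound 2 to compound 4 (0.49 log units; beyond the scatter), with the possibility of no change beyond the scatter kept open. Compound 4 is estimated at 800 nM in this assay, within a range from 200 nM to 3500 nM.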

Compound 4, concentration for 50% growth inhibition: 1650 nM
For compound 4 the middle estimate is 2.1-fold (0.31 log units) below the measured one; low and high end bracket the measured number.
By their numbers in this assay, from the lowest: compound 2; then compounds 4 and 1 (each within the scatter of the next); then compound 3.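

In this assay the chloro on the aromatic carbon between two ring nitrogen atoms now has a step of its own: hydrogen in its place gives a 6.3-fold higher number from compound 2 to compound 4 (0.80 log units; beyond the scatter) on an otherwise unchanged structure. Going by these compounds alone, this position therefore counts in this assay, a reading that the earlier compounds could not give, since each differed from compound 2 in two respects. With this chloro gone, compound 4 at 1650 nM and compound 1 at 1860 nM stand within the scatter of each other, so the clear separation of compound 2 from those two goes with the presence of the chloro in this comparison. No measurement at hand speaks to the reason for the step.

Going by these compounds, only chloro and hydrogen are seen at this position, so it remains open whether an amine, a methoxy group or a methyl group there would hold the number of compound 2 or lose it as hydrogen does. A single step also leaves open whether the same change would weigh equally on the background of compound 3, which has by far the highest number of the set.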